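The source may hold more compounds than are shown below. What is called first, only, known or untested is meant among the compounds shown, and "the series" means these compounds.

This cytotoxicity study rests on two measured compounds and one that still waits to be tested. Among the compounds with values here, compound 1 `COc1nc(N)c2ccn(COCCO)c2n1` is the first of them. In a functional assay on BSC-1 cells (Cercopithecidae) for cytotoxicity (on this read-out higher numbers stand for weaker inhibition and lower numbers for stronger inhibition), compound 1 gives > 100000 nM, which is a limit of the assay rather than a number. Compound 2 `OCCOCn1ccc2c(Cl)nc(Cl)nc21` shares the same core. In this assay compound 2 gives > 100000 nM, again a limit of the assay and not a measured number. Where compound 2 stands is thus told only by the limit of > 100000 nM in this assay, at which 2 of the 2 values shown sit, the edge of the read-out at which both measured compounds sit.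

Compound 3 `Nc1nc(Cl)nc2c1ccn2COCCO` has not yet been measured in this assay. It differs from compound 2 in one place: amino in place of chloro on an aromatic carbon. Within the data shown here, since both measured compounds sit at the limit, no step between measured compounds can be stated, and the data hold no evidence that the exchange of chloro for amino moves the read-out. Compound 3 is therefore expected to stay at the limit, so that the step of a number no higher from compound 2 to compound 3 (the limit leaves the size open) is estimated as none beyond the scatter. The estimate for compound 3 in this assay is 100000 nM, with a range from 50000 nM to 300000 nM.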

Compound 3, half-maximal inhibitory concentration: > 100000 nM
Compound 3 gave a limit, no number; the forecaster's own chance of this, stated with the estimate: 85%; the middle value lies on the limit itself.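

Compound 3 sits at the same limit of the assay as compound 1 and compound 2, so neither the step from compound 2 nor the step from compound 1 to compound 3 can be read in this assay: the limit of > 100000 nM in this assay, at which 3 of the 3 values shown sit.

The compounds shown leave open whether exchanging chloro, amino or methoxy on the shared core changes the read-out at all.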